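From Compound 1 to Compound 4 in Cytotoxicity

The source may hold more compounds than are shown below. What is called first, only, known or untested is meant among the compounds shown, and "the series" means these compounds.

Measured so far:
compound 1 `CC(CCNC(=O)c1c(Cl)cncc1Cl)N1CCC(C(Oc2ncccc2Cl)c2ccc(C(F)(F)F)cc2)CC1`: 16700 nM
compound 2 `CCO/N=C(/c1ccc(Br)cc1)C1CCN(C(C)(C)CCNC(=O)c2c(Cl)cncc2Cl)CC1`: 34000 nM
compound 3 `CCO/N=C(/c1ccc(Br)cc1)C1CCN(C(CC)CCNC(=O)c2c(C)cc[n+]([O-])c2C)CC1`: > 177000 nM

In an ADME assay on PBMC cells (Homo sapiens) for cytotoxicity (a lower number here means that less compound is tolerated, a higher number that more compound is tolerated), compound 1 gives 16700 nM, the lowest of the two numbers available, with compound 2 the nearest at 34000 nM, a gap beyond the usual scatter. For compound 3 the result is only a limit, > 177000 nM, so its position cannot be set against the others; the limit itself is noted as the limit of > 177000 nM in this assay, at which 1 of the 3 values shown sits.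

Compound 4 `CC(CCNC(=O)c1c(Cl)cncc1Cl)N1CCC(C(Oc2cccc(C#N)n2)c2ccc(C(F)(F)F)cc2)CC1` differs from compound 1 in one place: 6-cyanopyridin-2-yl in place of 3-chloropyridin-2-yl on an oxygen on a saturated carbon. For the measured compounds named here, no measured pair shows what this kind of change does here, so only a modest step is expected, if any, and most likely upward. Compound 4 is expected to give about 25000 nM, between 10000 nM and 60000 nM, which would mean a step of a 1.5-fold higher number from compound 1 to compound 4 (0.18 log units; within the scatter).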

Compound 4, half-maximal cytotoxic concentration: 15700 nM
Compound 4: the middle estimate sits 1.6-fold (0.20 log units) above what was measured, and the stated range covers the measured number.
By their numbers in this assay, from the lowest: compounds 4 and 1 (each within the scatter of the next); then compound 2. At a limit, above all of these: compound 3.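

In this assay, 6-cyanopyridin-2-yl in place of 3-chloropyridin-2-yl on an oxygen on a saturated carbon gives a 1.1-fold lower number from compound 1 to compound 4 (0.03 log units; within the scatter), the first pair measured at this position. At this place, then, the exchange of the chlorine for a nitrile, together with its new location on the pyridine ring, leaves the two compounds indistinguishable in this read-out. Nothing measured here accounts for this result.

As far as these compounds go, whether an amine or a carboxylic acid in this place would separate from compound 1 stays open. So does whether the same exchange would read alike on the core of compound 2.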